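The source may hold more compounds than are shown below. What is called first, only, known or untested is meant among the compounds shown, and "the series" means these compounds.

In an ADME assay on microsomes from liver (Mus musculus) for pharmacokinetics, read by LC-MS, using NADPH, with stated times of 5 min, 15 min and 30 min, tested at 10 uM (on this read-out lower numbers stand for slow clearance and higher numbers for fast clearance), compound 1 `C[C@H](NC(=O)c1cccc(F)c1)c1ccc(NC(=O)N2CC(c3cccnc3)C2)cc1` gives 60.9 mL.min-1.g-1, and compound 2 `C[C@H](NC(=O)C1CCOCC1)c1ccc(NC(=O)N2CC(c3cccnc3)C2)cc1` gives 58 mL.min-1.g-1. Compound 3 `C[C@H](NC(=O)c1cccc(F)c1)c1ccc(NC(=O)N2CC(c3ccc(N)nc3)C2)cc1` has no exact number in this assay and is reported only as a limit, < 25 mL.min-1.g-1. Compound 4 `C[C@H](NC(=O)C1CCOCC1)c1ccc(NC(=O)N2CC(c3ccc(N)nc3)C2)cc1` differs from compound 3 in one place, with oxan-4-yl in place of 3-fluorophenyl on a carbonyl carbon. The same exchange has been measured once, without the amino group, where it gave a 1.1-fold lower number from compound 1 to compound 2 (0.02 log units; within the scatter). The other measured step, amino in place of hydrogen on an aromatic carbon, gave an at least 2.4-fold lower number from compound 1 to compound 3 (0.38 log units; beyond the scatter), and compound 4 keeps that amino group. Going by the single exchange in a 1.1-fold lower number from compound 1 to compound 2 (0.02 log units; within the scatter), no change beyond the scatter is expected in this assay, and the expected step is a step that the limit leaves unreadable from compound 3 to compound 4. A report of compound 4 as a limit, like that of compound 3, would therefore be no surprise. For compound 4 the estimate is 22 mL.min-1.g-1, with an expected range from 12 mL.min-1.g-1 to 42 mL.min-1.g-1.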

Compound 4, intrinsic clearance in microsomes: < 25 mL.min-1.g-1
Compound 4: no number, only a limit (the forecaster's own chance of this, stated with the estimate: 65%); the middle value is on the limit's open side.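

In this assay compound 4 is reported only as a limit, < 25 mL.min-1.g-1 and so the step for oxan-4-yl in place of 3-fluorophenyl on a carbonyl carbon cannot be read with the amino group present. Going by these compounds alone, the amino in place of hydrogen on an aromatic carbon, earlier seen only with 3-fluorophenyl on the carbonyl carbon, now also lowers the number with oxan-4-yl there, giving an at least 2.3-fold lower number from compound 2 to compound 4 (0.36 log units; beyond the scatter). The two series therefore agree in direction, though not necessarily in size: the same change on two cores in this assay, an at least 2.4-fold lower number (0.38 log units; beyond the scatter) from compound 1 to compound 3 and an at least 2.3-fold lower number (0.36 log units; beyond the scatter) from compound 2 to compound 4; the limit leaves it open whether they differ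

The true size of these steps remains hidden, as the read-out stops at a floor here: the limit of < 25 mL.min-1.g-1 in this assay, at which 2 of the 4 values shown sit. As far as these compounds go, whether oxan-4-yl and 3-fluorophenyl differ once the amino group is present stays open, as does what a methylamino group or a carboxylic acid in its place would give.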